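Chloro on the phenyl ring of compound 2

This account rests on a few compounds, and the source may have more. Where it says the series, first, only, none or still open, it means among the compounds named here.

Measured in a functional assay on NCI-H226 cells (Homo sapiens) for inhibition, with a stated time of 48 h (a lower number here means a stronger inhibitor of growth, a higher number a weaker inhibitor of growth), so far
compound 1 `COc1c(C(=O)/C=C/c2ccc(Cl)cc2)c(O)c(Br)c2occc12` gives 2840 nM
compound 2 `C=CCc1c(O)c(C(=O)/C=C/c2ccccc2)c(OC)c2ccoc12` gives 1480 nM

Compound 2 at 1480 nM lies within the scatter of compound 1 at 2840 nM, so neither stands apart on these two numbers. Compound 3 `C=CCc1c(O)c(C(=O)/C=C/c2ccc(Cl)cc2)c(OC)c2ccoc12` keeps the core of compound 2 and takes chloro in place of hydrogen on an aromatic carbon, para to a large group, turning phenyl into 4-chlorophenyl (chloro in place of hydrogen on an aromatic carbon). Going by the values given here, no measured pair isolates this change. Compound 1 also carries 4-chlorophenyl but differs from compound 2 elsewhere, so it offers only weak guidance. No shift beyond the scatter is expected in this assay, and the estimated change is a 1.1-fold lower number from compound 2 to compound 3 (0.06 log units; within the scatter) at most a slight one. For compound 3 the expected value is 1300 nM (estimated range 550 nM to 3000 nM).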

Compound 3, concentration for 50% growth inhibition: 1520 nM
Beside the measured number, compound 3's estimate is 1.2-fold (0.07 log units) below it; the measured number falls inside the stated range.
By their numbers in this assay, from the lowest: compounds 2, 3 and 1 (each within the scatter of the next).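

Chloro in place of hydrogen on an aromatic carbon, para to a large group, now has a single-change reading in this assay: a 1.0-fold higher number from compound 2 to compound 3 (0.01 log units; within the scatter), so phenyl and 4-chlorophenyl are not told apart on these numbers. Allyl in place of bromo on an aromatic carbon, the other single-place change now available, reads in this assay as a 1.9-fold lower number from compound 1 to compound 3 (0.27 log units; within the scatter), so that place shows no separation either. No measurement is available that bears on either result.

Open, on these data alone, is whether an amine or a carboxylic acid on the same ring carbon as the chloro would give a step beyond the scatter. Also open, as far as these compounds go, is whether a longer chain in place of allyl would do so.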